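Shortening the chain on a selenium-containing core

The compounds below may be only part of what the source reports. "The series", "measured", "known", "first", "only" and "open" are said of these compounds alone.

Compound 1, `CC(C)CCNC(=O)c1ccccc1[Se][Se]c1ccccc1C(=O)NCCC(C)C`, gives > 500000 nM in a functional assay on MCF7 cells (Homo sapiens) for cytotoxicity, read by MTT assay, with a stated time of 24 h; a higher number here means a weaker inhibitor, a lower number a stronger inhibitor; this is a limit of the assay, not a number.
Compound 2, `CC(C)CCn1[se]c2ccccc2c1=O`, gives 29000 nM in this assay.

Among the two measured compounds, compound 2 holds the only numerical value in this assay. The other entry, for compound 1, sits at the limit of > 500000 nM in this assay, at which 1 of the 2 values shown sits, so no ranking between the two can be drawn beyond the fact that compound 2 gave a measurable result.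

Compound 3, `CCCCn1[se]c2ccccc2c1=O`, has not yet been measured. It differs from compound 2 by one small change: hydrogen in place of methyl on a saturated chain carbon bound to two saturated chain carbons. Put plainly, a methyl is cut from the chain attached to the nitrogen of the shared core, so the branched chain of compound 2 becomes a straight one in compound 3. Within the data shown here, no pair of measured compounds differs in only one place, so there is no measured step to guide the size of this change; a change of one carbon on a flexible chain is expected to move the value little, and no step beyond the usual scatter is anticipated in this assay.

Compound 3 is therefore expected to give about 35000 nM in this assay, with a plausible range from 12000 nM to 100000 nM, which would mean an estimated step of a 1.2-fold higher number from compound 2 to compound 3 (0.08 log units; within the scatter).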

Compound 3, half-maximal inhibitory concentration: 13800 nM
Estimate against measurement, compound 3: 2.5-fold (0.40 log units) above, within the range that was stated.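

The chain attached to the nitrogen of the shared core is a place where a small edit can be read: in this assay, cutting one methyl, so that isopentyl becomes butyl, gives a 2.1-fold lower number from compound 2 to compound 3 (0.32 log units; beyond the scatter). This is the only measured step among the compounds shown, and it shows that the branch on a saturated chain carbon bound to two saturated chain carbons can be removed with no loss of activity in these cells, although the step is modest. Nothing measured here tells what lies behind the lower number, and the step stands as an observation only.

On these data alone, a single step makes no pattern, and it remains open whether a shorter propyl chain, a longer chain, or an amine or a carboxylic acid at the end of the chain would move the number further. Among these compounds, compound 1 gives no step to read, as its entry is a limit of the assay and not a number, and the way its structure relates to the others differs in more than one place.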